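Adding a propyl group to compound 2

The source may report more compounds than this note shows. Statements on the series, on what has been measured and on what is new or still open speak of the compounds shown alone.

In a functional assay on the whole organism with Rattus norvegicus as the target (a lower number here means a stronger inhibitor, a higher number a weaker inhibitor), compound 1 (`O=c1oc2cc(OCCCN3CCN(Cc4ccc(Cl)cc4)CC3)ccc2c(O)c1[N+](=O)[O-]`) gives 1900 nM. Compound 2 (`O=c1oc2cc(OCC(O)CN3CCN(Cc4ccc(Cl)cc4)CC3)ccc2c(O)c1[N+](=O)[O-]`) is known only as a limit, < 2000 nM. Compound 3 (`CCCc1c(OCC(O)CN2CCN(Cc3ccc(Cl)cc3)CC2)ccc2c(O)c([N+](=O)[O-])c(=O)oc12`) has propyl in place of hydrogen on an aromatic carbon. Going by the values given here, the only measured step, a step that the limit leaves unreadable from compound 1 to compound 2, places hydroxy on the saturated chain rather than on an aromatic carbon, and its size stays unreadable, with the evidence ending at the limit of < 2000 nM in this assay, at which 1 of the 2 values shown sits. Among the compounds with values here, no measured step therefore sizes this change in this assay, and no shift beyond the scatter is expected, leaving the estimated step as a step that the limit leaves unreadable from compound 2 to compound 3. For compound 3 the estimated value is 1500 nM, with an expected range from 500 nM to 4000 nM.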

Compound 3, half-maximal inhibitory concentration: 2600 nM
Compound 3: the middle estimate sits 1.7-fold (0.24 log units) below what was measured, and the stated range covers the measured number.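

In this assay, propyl in place of hydrogen on an aromatic carbon gives an at least 1.3-fold higher number from compound 2 to compound 3 (0.11 log units; that floor lies within the scatter). Going by these compounds alone, this is the first step that can be read at all, and it is the first on this aromatic carbon, where the earlier compounds carry only hydrogen. Only a floor can be read, because compound 2 is known as a limit: the limit of < 2000 nM in this assay, at which 1 of the 3 values shown sits.

On these data alone, the true size of this step stays open, and the step placing hydroxy on the chain cannot be read. Also open, as far as these compounds go, is how methyl, an amine or a carboxylic acid on this aromatic carbon would compare with propyl.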